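The source may hold more compounds than are shown below. What is called first, only, known or untested is meant among the compounds shown, and "the series" means these compounds.

Working notes on the series. Three compounds sharing one core have numbers in a functional assay on HCT-116 cells (Homo sapiens) for cytotoxicity, read by MTT assay, with a stated time of 24 h; a higher number here means a weaker inhibitor, a lower number a stronger inhibitor. Compound 1 `COc1ccc(-n2cc(COc3c(/C=C\C(=O)O)ccc(OC)c3CC=C(C)C)nn2)cc1` gives 8700 nM. Compound 2 `COc1ccc(/C=C\C(=O)O)c(OCc2cn(-c3ccccc3)nn2)c1CC=C(C)C` gives 26000 nM. Compound 3 `COc1cccc(-n2cc(COc3c(/C=C\C(=O)O)ccc(OC)c3CC=C(C)C)nn2)c1` gives 21600 nM, the second highest of the three numbers; it lies within the scatter of compound 2 and is separated from compound 1 by a 2.5-fold higher number from compound 1 to compound 3 (0.39 log units; beyond the scatter). The measured steps all concern the methoxy on the ring carried by the aromatic nitrogen: a 3.0-fold higher number from compound 1 to compound 2 (0.48 log units; beyond the scatter) and a 2.5-fold higher number from compound 1 to compound 3 (0.39 log units; beyond the scatter) are both modest, while a 1.2-fold lower number from compound 2 to compound 3 (0.08 log units; within the scatter) stays within the scatter.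

Compound 4 `COc1ccc(/C=C\C(=O)O)c(OCc2cn(-c3nc4ccccc4s3)nn2)c1CC=C(C)C` differs from compound 3 by 1,3-benzothiazol-2-yl in place of 3-methoxyphenyl on an aromatic nitrogen. Going by the values given here, no measured step exchanges the whole group on that nitrogen for another ring system, so the steps seen so far only show that changes at this position have been modest at most; they give no direction for the new group. The number for compound 4 is therefore expected close to that of compound 3, a step of a 1.1-fold lower number from compound 3 to compound 4 (0.03 log units; within the scatter), with a wide range; the estimate for compound 4 is 20000 nM, between 6000 nM and 60000 nM.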

Compound 4, half-maximal inhibitory concentration: 16400 nM
Compound 4: the middle estimate sits 1.2-fold (0.09 log units) above what was measured, within the range that was stated.
By their numbers in this assay, from the lowest: compounds 1, 4, 3 and 2 (each within the scatter of the next, the first and the last beyond it).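

In this assay, going by these compounds alone, 1,3-benzothiazol-2-yl is the first group on the aromatic nitrogen that is not a phenyl ring, and the steps to it remain small: a 1.3-fold lower number from compound 3 to compound 4 (0.12 log units; within the scatter), a 1.6-fold lower number from compound 2 to compound 4 (0.20 log units; within the scatter) and a 1.9-fold higher number from compound 1 to compound 4 (0.28 log units; within the scatter). The position therefore accepts a five-membered aromatic ring with 2 hetero atoms in the entering group without a step beyond the scatter from any earlier compound, so compound 4 cannot be separated from compound 1, although compound 1 and compound 2 are separated. Nothing at hand bears on why this exchange changes the number so little.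

Still open, going by these compounds, is whether an amine or a carboxylic acid on the ring carried by the aromatic nitrogen would give a step beyond the scatter. Also open, on these data alone, is what a plain alkyl chain in place of that ring would do.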